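Carbamoyl in Place of Nitro: an Expected Cytotoxicity Value

The compounds below may be only part of what the source reports. "The series", "measured", "known", "first", "only" and "open" are said of these compounds alone.

Compound 1 `CCOC(=O)c1cnc(N2CCN(Cc3ccc(C(F)(F)F)cc3)CC2)nc1Oc1c(C)cc(-c2ccc(C#N)cc2)cc1C` gives > 125000 nM in an ADME assay on MT4 cells (Homo sapiens) for cytotoxicity, read by MTT assay, with a stated time of 4 days; a lower number here means that less compound is tolerated, a higher number that more compound is tolerated.
Compound 2 `CCOC(=O)c1cnc(N2CCN(Cc3ccc([N+](=O)[O-])cc3)CC2)nc1Oc1c(C)cc(-c2ccc(C#N)cc2)cc1C` gives > 125000 nM in this assay.

The value of compound 1 is a limit of the assay, not a number. The value of compound 2 is likewise a limit. Hence a step that the two limits leave unreadable from compound 1 to compound 2, as both sit at the limit of > 125000 nM in this assay, at which 2 of the 2 values shown sit. Compound 3 `CCOC(=O)c1cnc(N2CCN(Cc3ccc(C(N)=O)cc3)CC2)nc1Oc1c(C)cc(-c2ccc(C#N)cc2)cc1C` differs from compound 2 by carbamoyl in place of nitro on an aromatic carbon. Among the measured compounds shown here, the one measured step is unreadable, so no change beyond the scatter is expected: the step of a number no higher from compound 2 to compound 3 (the limit leaves the size open) is estimated to stay at the limit. Compound 3 is therefore expected to give 125000 nM, between 60000 nM and 300000 nM.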

Compound 3, half-maximal cytotoxic concentration: 66500 nM
The estimate for compound 3 lay 1.9-fold (0.27 log units) above the measured number; the measured number falls inside the stated range.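

Among the compounds shown here, with carbamoyl on the aromatic carbon para to a large group, compound 3 gives 66500 nM in this assay, the first value here that is a number and so the first that lets a step at this position be sized. The change gives an at least 1.8-fold lower number from compound 2 to compound 3 (0.27 log units; that floor lies within the scatter), and against trifluoromethyl it gives an at least 1.8-fold lower number from compound 1 to compound 3 (0.27 log units; that floor lies within the scatter). Compound 1 and compound 2 remain limits: the limit of > 125000 nM in this assay, at which 2 of the 3 values shown sit.

The compounds shown leave open whether the true size of either step goes beyond the scatter. They also leave open how an amine or a carboxylic acid at this place would read in this assay.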